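The source may report more compounds than this note shows. Statements on the series, on what has been measured and on what is new or still open speak of the compounds shown alone.

The measured compounds are:
Compound 1, `O=C(Nc1ccc(Oc2cc(C(F)(F)F)cc(C(F)(F)F)c2)cc1)c1ccccc1F`, which in an assay on HEK293 cells for inhibition of Toll-like receptor 8 (Homo sapiens), with a stated time of 16 h (on this read-out lower numbers stand for stronger inhibition and higher numbers for weaker inhibition), gives 3000 nM.
Compound 2, `O=C(Nc1ccc(Oc2cc(C(F)(F)F)cc(C(F)(F)F)c2)cc1)c1ccc(O)cc1F`, for which this assay reports only a limit of the assay, > 50000 nM.
Compound 3, `O=C(Nc1ccc(Oc2cc(F)cc(C(F)(F)F)c2)cc1)c1c(F)cccc1Cl`, which in this assay gives 1590 nM.

Compound 3 and compound 1 sit within the usual scatter of repeated measurements of each other, so the two cannot be told apart on these numbers. Among the compounds with values here, the only single-place step measured so far is an at least 16-fold higher number from compound 1 to compound 2 (1.22 log units; beyond the scatter), a large move towards weaker inhibition, with compound 2 sitting at the limit of > 50000 nM in this assay, at which 1 of the 3 values shown sits. That step concerns a hydroxy group entering elsewhere in the molecule and does not touch the carbon changed next.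

Compound 4, `O=C(Nc1ccc(Oc2cc(I)cc(C(F)(F)F)c2)cc1)c1c(F)cccc1Cl`, differs from compound 3 by iodo in place of fluoro on an aromatic carbon. Within the data shown here, no measured step shows what an exchange of one halogen for another at this carbon does; compound 1 and compound 3 differ in more than one place, so their values give no single reading on it either. The expectation in this assay is therefore a step no larger than the scatter, in either direction, expressed as a 1.3-fold lower number from compound 3 to compound 4 (0.12 log units; within the scatter). Compound 4 is estimated to give 1200 nM, within a range from 400 nM to 4000 nM.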

Compound 4, half-maximal inhibitory concentration: 5000 nM
The estimate for compound 4 lay 4.2-fold (0.62 log units) below the measured number; the whole stated range lies below it.
By their numbers in this assay, from the lowest: compounds 3, 1 and 4 (each within the scatter of the next, the first and the last beyond it). At a limit, above all of these: compound 2.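

In this assay, within the data shown here, this carbon, meta to a trifluoromethyl group, now has a direct reading for an exchange of one halogen for another, which the earlier compounds could not give: a 3.1-fold higher number from compound 3 to compound 4 (0.50 log units; beyond the scatter), a modest move towards weaker inhibition. The exchange therefore matters at this position, even though the group that leaves and the group that enters are each a single heavy atom with no hydrogen-bond donors or acceptors and no net charge. Nothing among the compounds shown accounts for this step, so its cause remains unassigned.

With only fluoro and iodo compared at this carbon, the compounds shown leave open whether chloro or bromo would give values closer to compound 3 or to compound 4, and so whether the values follow the size of the halogen at all, or whether a non-halogen group such as an amine, a methoxy group or a nitrile would be tolerated here. They also leave open whether the same exchange would produce a step of similar size on the rest of the molecule as it stands in compound 1.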